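This account rests on a few compounds, and the source may have more. Where it says the series, first, only, none or still open, it means among the compounds named here.

Working notes on the series. Within the data shown here, compound 1, `Fc1cccc(-c2nc(Nc3ccccc3)c3ccccc3n2)c1`, is the first member with a value. In a functional assay on U2OS cells (Homo sapiens) for cytotoxicity, read by MTT assay, with a stated time of 48 h (on this read-out lower numbers stand for stronger inhibition and higher numbers for weaker inhibition), compound 1 gives > 50000 nM, which is a limit of the assay rather than a number. Compound 2, `Fc1ccc(Nc2nc(-c3cccc(F)c3)nc3ccc(F)cc23)cc1`, carries two further fluoro substituents on the shared core and the aniline part. In this assay compound 2 gives > 50000 nM, again a limit and not a number. Where compound 2 stands is therefore fixed only by the limit of > 50000 nM in this assay, at which 2 of the 2 values shown sit: both values shown sit at the same limit, and no step between measured compounds can be counted.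

Compound 3, `Fc1cccc(-c2nc(Nc3ccc(Cl)cc3)c3cc(F)ccc3n2)c1`, differs from compound 2 in one place: chloro in place of fluoro on an aromatic carbon, a chloro in place of a fluoro on an aromatic carbon. With both measured values at the limit, no direction can be read from the series; the change is small and the step that the limit leaves unreadable from compound 2 to compound 3 is expected to stay within the scatter rather than move the read-out. Compound 3 is therefore estimated at 60000 nM in this assay, with a range from 15000 nM to 200000 nM, most likely reported again only as a limit.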

Compound 3, half-maximal inhibitory concentration: 38400 nM
For compound 3 the middle estimate is 1.6-fold (0.19 log units) above the measured one; measured number inside the range.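

In this assay, among these compounds, compound 3 is the first member of the series to give a number rather than a limit, 38400 nM, so the read-out can now register activity. On the aromatic carbon para to a large group, going from (4-fluorophenyl)amino to (4-chlorophenyl)amino gives an at least 1.3-fold lower number from compound 2 to compound 3 (0.11 log units; that floor lies within the scatter), which is only a floor on the step, and its true size may be larger. The reading of this step rests on a limit of the assay, which compound 2 gives in place of a number: the limit of > 50000 nM in this assay, at which 2 of the 3 values shown sit.

With one number in the series, no trend across groups at this position can be stated, and the step from fluoro to chloro alone does not show whether a larger halogen such as bromo or iodo would carry the read-out further. Going by these compounds, how a methoxy group, a dimethylamino group or a carboxylic acid would read at this same position also stays open.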